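From methoxy to fluoro on an aromatic carbon

This account rests on a few compounds, and the source may have more. Where it says the series, first, only, none or still open, it means among the compounds named here.

Measured in a functional assay on PC-3 cells (Homo sapiens) for antiproliferative activity, read by WST assay, with a stated time of 72 h; a lower number here means a stronger inhibitor of growth, a higher number a weaker inhibitor of growth:
Compound 1 `C#Cc1cccc(N/N=N/c2ccc(C(=N)N)cc2)c1` gives 18000 nM
Compound 2 `COc1ccc(C#Cc2cccc(N/N=N/c3ccc(C(=N)N)cc3)c2)cc1` gives 5000 nM
Compound 3 `C#Cc1ccccc1N/N=N/c1ccc(C(=N)N)cc1` gives > 50000 nM

Compound 2 stands lowest of the two numbers available in this assay, at 5000 nM, and its nearest neighbour is compound 1 at 18000 nM. For compound 3 the value > 50000 nM is a limit and not a number.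

The next compound to be tested is compound 4 `N=C(N)c1ccc(/N=N/Nc2cccc(C#Cc3ccc(F)cc3)c2)cc1`. Its difference from compound 2 is fluoro in place of methoxy on an aromatic carbon, which in words is fluoro in place of methoxy on an aromatic carbon, para to a large group. For the measured compounds named here, no measured step exchanges the methoxy itself. Going by the values given here, the only step bearing on the change is the one that introduced the whole 4-methoxyphenyl in place of hydrogen on a triple-bonded carbon, and it gave a 3.6-fold lower number from compound 1 to compound 2 (0.56 log units; beyond the scatter). Compound 4 keeps the ring added in that modest step and alters only the group on it, so a smaller change is expected, with no clear direction and probably nothing beyond the scatter. The step expected is a 1.2-fold higher number from compound 2 to compound 4 (0.08 log units; within the scatter). Compound 4 is estimated at 6000 nM, with an expected range from 2500 nM to 15000 nM.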

Compound 4, concentration for 50% growth inhibition: 5300 nM
Beside the measured number, compound 4's estimate is 1.1-fold (0.05 log units) above it; low and high end bracket the measured number.
By their numbers in this assay, from the lowest: compounds 2 and 4 (each within the scatter of the next); then compound 1. At a limit, above all of these: compound 3.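

The exchange of methoxy for fluoro on an aromatic carbon, para to a large group, gives a 1.1-fold higher number from compound 2 to compound 4 (0.03 log units; within the scatter) in this assay and is the first step shown that alters the group on the added ring and not the presence of the ring. The second substituted ring repeats on the triple-bonded carbon what the first one did: 4-fluorophenyl in place of hydrogen gives a 3.4-fold lower number from compound 1 to compound 4 (0.53 log units; beyond the scatter) and stands alongside a 3.6-fold lower number from compound 1 to compound 2 (0.56 log units; beyond the scatter) as a modest step beyond the scatter. The step away from compound 1 therefore does not depend on methoxy alone, and at this position the two groups cannot be told apart in this read-out.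

As far as these compounds go, whether an amine, a carboxylic acid or a plain hydrogen on that ring would hold the number at this level stays open, as does whether any other group here could bring the number clearly lower than these two compounds do. No measurement shown here speaks to why methoxy and fluoro read alike.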